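A few compounds are considered here, and "the series" means these few. Any claim that something is new, unique, unknown or untested is made for them only; others in the source may bear on it.

Measured compounds:
Compound 1, `O=c1ccc2cc(OCc3cc(-c4cccc(Cl)c4)no3)ccc2o1`: 42100 nM
Compound 2, `O=c1ccc2cc(OCc3cc(-c4ccc(Cl)cc4)no3)ccc2o1`: 55800 nM
Compound 3, `O=c1ccc2cc(OCc3cn(-c4ccccc4)nn3)ccc2o1`: 51500 nM

All three were read in a functional assay on HCT-116 cells (Homo sapiens) for cytotoxicity, read by MTT assay, with a stated time of 48 h; on this read-out lower numbers stand for stronger inhibition and higher numbers for weaker inhibition. The number for compound 3 lies within the usual scatter of both compound 1 and compound 2, so nothing in these data sets it apart from either. Going by the values given here, the only step between measured compounds that differ in one place is a 1.3-fold higher number from compound 1 to compound 2 (0.12 log units; within the scatter), and it too stays within the scatter.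

Compound 4, `COc1ccc(-n2cc(COc3ccc4oc(=O)ccc4c3)nn2)cc1`, differs from compound 3 by methoxy in place of hydrogen on an aromatic carbon. Among the compounds with values here, no measured step replaces a hydrogen with a group of this kind, so nothing bears on the change directly; the one step in hand shows that exchanging one chlorophenyl for another on the pendant ring left the number essentially unmoved. The expected step in this assay is therefore none beyond the scatter, and a 1.0-fold lower number from compound 3 to compound 4 (0.01 log units; within the scatter) is estimated to be small. Compound 4 is expected to give about 50000 nM, with a range from 20000 nM to 130000 nM.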

Compound 4, half-maximal inhibitory concentration: 37800 nM
For compound 4 the middle estimate is 1.3-fold (0.12 log units) above the measured one; measured number inside the range.
By their numbers in this assay, from the lowest: compounds 4, 1, 3 and 2 (each within the scatter of the next).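

Placing methoxy on the aromatic carbon para to a large group gives, in this assay, a 1.4-fold lower number from compound 3 to compound 4 (0.13 log units; within the scatter), and this is the first replacement of a hydrogen on this ring among the compounds shown. The earlier step only exchanged one chlorophenyl for another, whereas this one shows that the phenyl of compound 3 can become 4-methoxyphenyl with no change in the number beyond the scatter. Nothing at hand explains this result.

As far as these compounds go, whether a different group at this place, such as an amine or a carboxylic acid, would move the number beyond the scatter remains open. So does whether methoxy on another carbon of this ring would do so.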